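This account rests on a few compounds, and the source may have more. Where it says the series, first, only, none or still open, it means among the compounds named here.

Measured so far in an assay on CHO cells for displacement of a labelled ligand from melanin-concentrating hormone receptor 1 (Homo sapiens), read by scintillation counting; a lower number here means a stronger inhibitor, a higher number a weaker inhibitor:

compound 1 `COC[C@H]1O[C@H](OCc2ccc3ccccc3c2)[C@H](NC(=O)CCCN=C(N)N)[C@@H](OCc2ccc(Cl)cc2)[C@@H]1O`: 920 nM
compound 2 `COC[C@H]1O[C@@H](OCc2ccc(Cl)cc2)[C@H](NC(=O)CCCN=C(N)N)[C@@H](OCc2ccc(Cl)cc2)[C@@H]1O`: 1660 nM
compound 3 `COC[C@H]1O[C@H](OCc2ccc(Cl)cc2)[C@H](NC(=O)CCCN=C(N)N)[C@@H](OCc2ccc(Cl)cc2)[C@@H]1O`: 120 nM

Compound 2 has the highest of the three numbers in this assay, but compound 1 sits within the scatter of it, so the two cannot be ranked. Compound 3 is clearly stronger: the step of a 14-fold lower number from compound 2 to compound 3 (1.14 log units; beyond the scatter) is large, and it rests on (the fact that compounds 2 and 3 differ only in the configuration as drawn), one stereocentre of the core being drawn the other way round.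

Compound 4 `COC[C@H]1O[C@@H](OCc2ccc3ccccc3c2)[C@H](NC(=O)CCCN=C(N)N)[C@@H](OCc2ccc(Cl)cc2)[C@@H]1O` keeps the configuration of compound 2 and makes one change: naphthalen-2-yl in place of 4-chlorophenyl on a saturated chain carbon bound to an oxygen on a saturated carbon. The same swap has been seen once before, in the opposite direction, within the other configuration of the core: there, a 7.7-fold lower number from compound 1 to compound 3 (0.88 log units; beyond the scatter), a modest gain on moving from the naphthyl to the chlorophenyl group. Read backwards, that step suggests that putting naphthalen-2-yl onto compound 2 should raise the number in this assay by a modest to large amount, giving a weaker inhibitor, though whether the swap costs the same in this configuration is untested.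

Compound 4 is therefore expected to give about 7000 nM, within 1800 nM to 28000 nM. That estimate means a step of a 4.2-fold higher number from compound 2 to compound 4 (0.62 log units; beyond the scatter), expected to be beyond the scatter.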

Compound 4, half-maximal inhibitory concentration: 1750 nM
For compound 4 the middle estimate is 4.0-fold (0.60 log units) above the measured one, outside the stated range (below it).
By their numbers in this assay, from the lowest: compound 3; then compounds 1, 2 and 4 (each within the scatter of the next).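

The swap from 4-chlorophenyl to naphthalen-2-yl at this place does not carry one fixed cost in this assay: in the configuration of compound 2 it gives a 1.1-fold higher number from compound 2 to compound 4 (0.02 log units; within the scatter), so the two groups cannot be told apart on that core. The effect of the same swap therefore differs with the configuration of the core, as the two matched pairs show: the same change on two cores in this assay, a 7.7-fold lower number (0.88 log units; beyond the scatter) from compound 1 to compound 3 and a 1.1-fold lower number (0.02 log units; within the scatter) from compound 4 to compound 2, 7.3-fold (0.86 log units) apart, beyond the scatter of two such steps. The stereocentre shows the same dependence from the other side, for with 4-chlorophenyl there is a 14-fold lower number from compound 2 to compound 3 (1.14 log units; beyond the scatter), while with naphthalen-2-yl there is only a 1.9-fold higher number from compound 1 to compound 4 (0.28 log units; within the scatter), so among these four compounds the clear gain appears only when 4-chlorophenyl and the configuration of compound 3 occur together: the fact that compounds 1 and 4 differ only in the configuration as drawn.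

Going by these compounds alone, still open is whether that gain needs the chlorine itself or only a single aromatic ring, which a plain phenyl or a 4-fluorophenyl group at this place, tested in both configurations, could begin to settle. The compounds shown also give no reason why the group and the configuration act together in this way.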